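Amide substituent change in an oxadiazolyl azetidine series

This account rests on a few compounds, and the source may have more. Where it says the series, first, only, none or still open, it means among the compounds named here.

Measured so far:
compound 1 `O=C(c1ccccc1F)N1CC[C@H]1c1nc(-c2cccc(F)c2)no1` gives > 10000 nM
compound 2 `CC1CCCC(C(=O)N2CC(c3nc(-c4cccc(Cl)c4)no3)C2)C1` gives 410 nM

In an assay on HEK293 cells for positive allosteric modulation of metabotropic glutamate receptor 5 (Homo sapiens), read by FLIPR (a lower number here means that less compound is needed, a higher number that more compound is needed for the effect), compound 2 gives 410 nM. For compound 1 the result in this assay is a limit, > 10000 nM, and not a number. Compound 2 therefore stands as the only numbered result in this set; the one other result is the limit described by the limit of > 10000 nM in this assay, at which 1 of the 2 values shown sits. No step between two numbered compounds is shown, so no measured step size is available for comparison.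

Compound 3 `O=C(C1CCC1)N1CC(c2nc(-c3cccc(Cl)c3)no2)C1` is not yet measured in this assay. It differs from compound 2 as follows: cyclobutyl in place of 3-methylcyclohexyl on a carbonyl carbon.

The step of a 3.7-fold higher number from compound 2 to compound 3 (0.56 log units; beyond the scatter) is expected to go beyond the scatter, in the direction of more compound being needed. Compound 3 is estimated at 1500 nM, with a range from 400 nM to 6000 nM.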

Compound 3, half-maximal effective concentration: > 10000 nM
Compound 3 gave a limit, no number (the forecaster's own chance of this, stated with the estimate: 15%); at least 6.6-fold (0.82 log units) between middle value and limit.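

In this assay, the substituent on the carbonyl carbon now has its first measured step: cyclobutyl in place of 3-methylcyclohexyl gives an at least 24-fold higher number from compound 2 to compound 3 (1.38 log units; beyond the scatter). The result for compound 3 is a limit and not a number, so this step has a lower bound only and its full size cannot be read. The series is therefore sensitive to this one change, and a numbered result is now the exception in the set: the limit of > 10000 nM in this assay, at which 2 of the 3 values shown sit.

The compounds shown leave open whether the ring size or the methyl group accounts for the loss; cyclohexyl and cyclopentyl on the same carbonyl carbon would separate the two. Also open, as far as these compounds go, is whether an open chain such as isobutyl, or an aromatic phenyl group, at this place would give a numbered result.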